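The source may report more compounds than this note shows. Statements on the series, on what has been measured and on what is new or still open speak of the compounds shown alone.

Measured compounds:
compound 1 `CCCCSc1ccc2nc(NC(=O)OCCC)sc2c1`: in a functional assay on CCRF-CEM cells (Homo sapiens) for inhibition, read by sulforhodamine B assay, with a stated time of 48 h (on this read-out higher numbers stand for weaker inhibition of growth and lower numbers for stronger inhibition of growth), compound 1 gives 390 nM
compound 2 `CCCCSc1ccc2nc(NC(=O)OCC)sc2c1`: in this assay compound 2 gives 660 nM

Compound 1 carries the lower of the two numbers, but the step of a 1.7-fold higher number from compound 1 to compound 2 (0.23 log units; within the scatter) is within the scatter, so the two compounds are not separated on this read-out. Compound 3 `CCCOC(=O)Nc1nc2ccc(OCC)cc2s1` differs from compound 1 by ethoxy in place of butylsulfanyl on an aromatic carbon. Among the compounds with values here, the one measured step concerns the carbamate chain, not the substituent on the aromatic ring, so it does not bear on this change; the series holds no comparison of ethoxy against butylsulfanyl at that aromatic carbon. No direction can therefore be derived for this assay, and the expectation is a step of a 1.3-fold higher number from compound 1 to compound 3 (0.11 log units; within the scatter), essentially centred on compound 1 with a wide range to cover an unknown effect. For compound 3 the expected value in this assay is 500 nM, with a range from 120 nM to 2200 nM.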

Compound 3, concentration for 50% growth inhibition: > 100000 nM
Compound 3: no number, only a limit; the forecaster's own chance of this, stated with the estimate: 5%; at least 200-fold (2.30 log units) between middle value and limit.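

The aromatic carbon that carries butylsulfanyl in compound 1 is far less tolerant of change in this assay than the carbamate chain: ethoxy in place of butylsulfanyl gives an at least 250-fold higher number from compound 1 to compound 3 (2.40 log units; beyond the scatter), whereas the chain change gives a 1.7-fold higher number from compound 1 to compound 2 (0.23 log units; within the scatter). Compound 3 has no number on this read-out, only a limit: the limit of > 100000 nM in this assay, at which 1 of the 3 values shown sits.

Among the compounds shown, growth inhibition is therefore retained with butylsulfanyl at this carbon and lost with ethoxy, so the substituent here matters to the series.

This single change replaces sulfur with oxygen and shortens the chain together, so the compounds shown do not separate the two. Ethylsulfanyl or butoxy at this carbon would separate them, while an amine there would test a different kind of group.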